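The source may hold more compounds than are shown below. What is called first, only, known or untested is meant among the compounds shown, and "the series" means these compounds.

Measured compounds:
compound 1, `C=CCn1c(=O)c2[nH]cnc2n(CCC)c1=O`, 1600 nM
compound 2, `CCCn1c(=O)n(C)c(=O)c2c1ncn2CCC(=O)O`, > 100000 nM

In a functional assay (trachea) with Cavia porcellus as the target (on this read-out lower numbers stand for an effect already at smaller amounts and higher numbers for an effect only at larger amounts of compound), compound 1 gives 1600 nM. For compound 2 this assay reports no number but only a limit, > 100000 nM. That is the limit of > 100000 nM in this assay, at which 1 of the 2 values shown sits, so compound 2 stands at the upper edge of the numbers shown, with nothing to say how far beyond it the true value lies.

Compound 3, `CCCn1c(=O)n(C)c(=O)c2c1ncn2CCOCC`, has not yet been measured in this assay. It differs from compound 2 in a single place: ethoxy in place of carboxy on a saturated chain carbon, two bonds along the chain from an aromatic nitrogen. Among the compounds with values here, no step between measured compounds covers this change, and because compound 2 rests on the limit (the limit of > 100000 nM in this assay, at which 1 of the 2 values shown sits), the direction is the only thing the data fix: any number obtained for compound 3 would read as a move toward lower values, while the size of that move stays open. The expected step is an at least 5.0-fold lower number from compound 2 to compound 3 (0.69 log units; beyond the scatter). Compound 3 is estimated to give 20000 nM in this assay, in a range from 3000 nM to 100000 nM, with a real chance that the assay again reports only a limit.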

Compound 3, half-maximal effective concentration: 4600 nM
Estimate against measurement, compound 3: 4.3-fold (0.64 log units) above; the range from low to high includes it.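

In this assay, ethoxy in place of carboxy on a saturated chain carbon, two bonds along the chain from an aromatic nitrogen, gives an at least 21-fold lower number from compound 2 to compound 3 (1.33 log units; beyond the scatter). The position is shown to accept a chain that gives a measured number, as compound 3 reaches 4600 nM. This step starts from a limit for compound 2, which carries the 2-carboxyethyl chain at this place, so its true size remains unknown: the limit of > 100000 nM in this assay, at which 1 of the 3 values shown sits.

The compounds shown leave open whether the change in this assay follows from losing carboxy or from gaining ethoxy, a question that a simple propyl chain, hydroxy or an amine at the same chain carbon could help to separate. From the compounds shown here alone, compound 1 differs from compound 2 and compound 3 in more than one place, so it cannot show how this chain acts on its own, and how a longer ether chain would read also stays open.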